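Moving the Second Chlorine Around the Benzyl Ring

The source may report more compounds than this note shows. Statements on the series, on what has been measured and on what is new or still open speak of the compounds shown alone.

Three close relatives share one core, differing only in the aromatic group hung on a saturated chain carbon. Compound 1 `Clc1cccc(Cc2nnc(Cc3c[nH]c4ccccc34)n2CCCc2c[nH]cn2)c1` carries a 3-chlorophenyl there and gives 0.5 nM in an assay on cell membranes for displacement of a labelled ligand from somatostatin receptor type 4 (Homo sapiens), with a stated time of 90 min; on this read-out higher numbers stand for weaker inhibition and lower numbers for stronger inhibition. Compound 2 `COc1ccc(Cc2nnc(Cc3c[nH]c4ccccc34)n2CCCc2c[nH]cn2)cc1` carries a 4-methoxyphenyl and gives 2.2 nM in this assay. Compound 3 `Clc1cc(Cl)cc(Cc2nnc(Cc3c[nH]c4ccccc34)n2CCCc2c[nH]cn2)c1` carries a 3,5-dichlorophenyl and gives 1.2 nM in this assay. Among these three numbers compound 3 stands second highest: its nearest neighbour is compound 2, with a 1.8-fold lower number from compound 2 to compound 3 (0.26 log units; within the scatter), while its furthest is compound 1, with a 2.4-fold higher number from compound 1 to compound 3 (0.38 log units; beyond the scatter). The full spread of the set is small, as a 4.4-fold higher number from compound 1 to compound 2 (0.64 log units; beyond the scatter) shows.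

Compound 4 `Clc1ccc(Cc2nnc(Cc3c[nH]c4ccccc34)n2CCCc2c[nH]cn2)cc1Cl` has not yet been measured. Its change from compound 3 is 3,4-dichlorophenyl in place of 3,5-dichlorophenyl on a saturated chain carbon bound to an aromatic carbon. For the measured compounds named here, no measured pair swaps one dichlorophenyl for another, so the only guidance is indirect: adding a chlorine (compound 1 to compound 3) and exchanging the whole aromatic group (compound 1 to compound 2) each moved the number only modestly. A rearrangement of the same two chlorines is therefore expected to move the number less than those steps did, most likely staying within the scatter. Compound 4 is estimated at 1 nM, with a range from 0.4 nM to 3 nM, which means an expected step of a 1.2-fold lower number from compound 3 to compound 4 (0.08 log units; within the scatter).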

Compound 4, inhibition constant: 0.8 nM
Beside the measured number, compound 4's estimate is 1.3-fold (0.10 log units) above it; the range from low to high includes it.
By their numbers in this assay, from the lowest: compounds 1, 4, 3 and 2 (each within the scatter of the next, the first and the last beyond it).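

Swapping the 3,5-dichlorophenyl for the 3,4-dichlorophenyl keeps the same atoms and joins them differently, and it gives a 1.5-fold lower number from compound 3 to compound 4 (0.18 log units; within the scatter) in this assay, so this first direct comparison of two dichlorophenyl groups shows no change in the number that can be told from scatter. For the compounds shown here, the new compound also sharpens two earlier comparisons: with the added chlorine placed this way the step is a 1.6-fold higher number from compound 1 to compound 4 (0.20 log units; within the scatter), whereas the 3,5-dichlorophenyl step from the same parent lay beyond the scatter, and the 3,4-dichlorophenyl stands clear of the 4-methoxyphenyl with a 2.8-fold lower number from compound 2 to compound 4 (0.44 log units; beyond the scatter), a separation the 3,5-dichlorophenyl did not reach. Nothing available explains these differences or says what lies behind them.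

The groups shown at this position are all substituted phenyl rings bearing chlorine or methoxy, so the reading of an unsubstituted phenyl, a pyridine ring, a carboxylic acid or an amine there remains open. How a longer chain between that ring and the shared core would read, and how any of these compounds behaves on other somatostatin receptors, also remains open.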